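The source may report more compounds than this note shows. Statements on the series, on what has been measured and on what is new or still open speak of the compounds shown alone.

Compound 3 `Cc1cc(C(=O)Nc2cccc(-c3oc4cc(-c5ccc(F)cc5)ccc4c(=O)c3O)c2)ccc1F` gives 7440 nM in a functional assay on MDA-MB-231 cells (Homo sapiens) for antiproliferative activity, read by CCK-8 assay, with a stated time of 72 h (a higher number here means a weaker inhibitor, a lower number a stronger inhibitor), the second highest of the three numbers measured. Compound 1 `O=C(Nc1cccc(-c2oc3cc(-c4ccc(F)cc4)ccc3c(=O)c2O)c1)c1ccccc1F` gives 7240 nM, and the step of a 1.0-fold higher number from compound 1 to compound 3 (0.01 log units; within the scatter) is within the scatter. Compound 2 `O=C(Nc1cccc(-c2oc3cc(-c4ccc(F)cc4)ccc3c(=O)c2O)c1)c1ccc(C(F)(F)F)cc1` gives 29400 nM; the step of a 4.0-fold lower number from compound 2 to compound 3 (0.60 log units; beyond the scatter) is modest but beyond the scatter. Compound 4 `CCCc1ccc(C(=O)Nc2cccc(-c3oc4cc(-c5ccc(F)cc5)ccc4c(=O)c3O)c2)cc1` carries the change (4-propylphenyl in place of 4-fluoro-3-methylphenyl on a carbonyl carbon). Among the measured compounds shown here, of the steps around compound 3, a 1.0-fold higher number from compound 1 to compound 3 (0.01 log units; within the scatter) was flat and a 4.1-fold higher number from compound 1 to compound 2 (0.61 log units; beyond the scatter) went to a weaker inhibitor; no propyl analogue has been measured, so the direction is open. A small rise in this assay is therefore expected, a 1.6-fold higher number from compound 3 to compound 4 (0.21 log units; within the scatter), with wide uncertainty. Compound 4 is estimated at 12000 nM, in the range 4500 nM to 35000 nM.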

Compound 4, half-maximal inhibitory concentration: 32200 nM
The estimate for compound 4 lay 2.7-fold (0.43 log units) below the measured number; low and high end bracket the measured number.
By their numbers in this assay, from the lowest: compounds 1 and 3 (each within the scatter of the next); then compounds 2 and 4 (each within the scatter of the next).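

In this assay, a 1.1-fold higher number from compound 2 to compound 4 (0.04 log units; within the scatter) does not separate propyl from trifluoromethyl on an aromatic carbon. Both a 4.3-fold higher number from compound 3 to compound 4 (0.64 log units; beyond the scatter) and a 4.4-fold higher number from compound 1 to compound 4 (0.65 log units; beyond the scatter) are modest steps to a weaker inhibitor, so 4-propylphenyl on this carbonyl carbon falls with compound 2, apart from compound 1 and compound 3. No supporting measurement bears on the reason for this grouping. Still open, from the compounds shown here alone, is whether an unsubstituted phenyl or a longer chain such as butyl would group with compound 2 and compound 4. Going by these compounds, an amine or a carboxylic acid on this ring is equally open.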